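A few compounds are considered here, and "the series" means these few. Any claim that something is new, unique, unknown or untested is made for them only; others in the source may bear on it.

Measured so far:
compound 1, `COc1cc(-c2nn(-c3cccc(NC(=O)c4ccc(Cl)c(C(F)(F)F)c4)c3)cc2-c2ccncc2)ccc1Cl`: > 32500 nM
compound 2, `COc1cc(-c2nn(-c3cccc(NC(=O)Nc4ccc(Cl)c(C(F)(F)F)c4)c3)cc2-c2ccncc2)ccc1Cl`: 19100 nM

Both values come from a functional assay on SK-MEL-28 cells (Homo sapiens) for inhibition, read by sulforhodamine B assay, with a stated time of 48 h; a lower number here means that less compound is tolerated, a higher number that more compound is tolerated. The value of compound 1 is a limit of that assay, not a number. Compound 2 therefore gives the only number shown, at 19100 nM, and stands alone as a measured point.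

Compound 3, `COc1cc(-c2nn(-c3cccc(NC(=O)c4ccccc4)c3)cc2-c2ccncc2)ccc1Cl`, differs from compound 2 in one place: phenyl in place of (4-chloro-3-(trifluoromethyl)phenyl)amino on a carbonyl carbon. Among the measured compounds shown here, only one measured step bears on this change, an at least 1.7-fold lower number from compound 1 to compound 2 (0.23 log units; that floor lies within the scatter), which touched the same carbonyl carbon in the opposite direction; its size is known only as a floor because one of its two values sits at the limit of > 32500 nM in this assay, at which 1 of the 2 values shown sits. Taking that amino group off the carbonyl again, with phenyl in its place, is expected to move the number back up, by roughly a 1.6-fold higher number from compound 2 to compound 3 (0.20 log units; within the scatter), with a real chance that the assay again returns only a limit. Compound 3 is thus estimated at 30000 nM, within 12000 nM to 80000 nM.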

Compound 3, concentration lethal to 50% of the cells: > 100000 nM
Compound 3: only a limit was reported; the forecaster's own chance of this, stated with the estimate: 45%; at least 3.3-fold (0.52 log units) between middle value and limit.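

In this assay, replacing (4-chloro-3-(trifluoromethyl)phenyl)amino with phenyl on the carbonyl carbon gives a step that can now be told from the scatter: an at least 5.2-fold higher number from compound 2 to compound 3 (0.71 log units; beyond the scatter). The value of compound 3 is a limit of the assay, not a number, so this step gives only a floor: the limit of > 100000 nM in this assay, at which 1 of the 3 values shown sits. The value of compound 1 is also a limit, and the step between compound 1 and compound 3 cannot be read: the limit of > 32500 nM in this assay, at which 1 of the 3 values shown sits.

The compounds shown leave open how much of the step from the amino-linked group to phenyl belongs to the amino nitrogen and how much to the chlorine and trifluoromethyl on the ring, since that step changes them together. They also leave open how a plain phenylamino or a benzylamino group on this carbonyl carbon would read in this assay.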